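The source may hold more compounds than are shown below. What is called first, only, known or untested is meant among the compounds shown, and "the series" means these compounds.

Compound 1 `COc1ccc(NC(=O)c2cccc(/C=C3\CC(=O)N(c4ccccc4)C3=O)c2)c(C)c1` was tested in an ADME assay on HCT-116 cells (Homo sapiens) for cytotoxicity, read by MTT assay, with a stated time of 72 h; a higher number here means a weaker inhibitor, a lower number a stronger inhibitor. In this assay compound 1 gives > 100000 nM, which is a limit of the assay rather than a measured number. Two related compounds were measured alongside it. Compound 2 `Cc1ccc(N2C(=O)C/C(=C\c3cccc(C(=O)Nc4ccc(Cl)cc4)c3)C2=O)cc1` gives in this assay > 100000 nM, again a limit. Compound 3 `O=C(Nc1ccc(Cl)cc1)c1cccc(/C=C2\CC(=O)N(Cc3ccccc3)C2=O)c1` gives in this assay > 100000 nM, also a limit. Among the measured compounds shown here, the one single-point step among them, a step that the two limits leave unreadable from compound 2 to compound 3, is not readable: both of its ends are limits. For the measured compounds named here, compound 1 thus stands at the limit of > 100000 nM in this assay, at which 3 of the 3 values shown sit, and no measured step offers a size to work from.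

The compound still to be measured is compound 4 `CCOc1ccc(NC(=O)c2cccc(/C=C3\CC(=O)N(c4ccccc4)C3=O)c2)cc1`. It differs from compound 1 by 4-ethoxyphenyl in place of 4-methoxy-2-methylphenyl on an amide-type nitrogen. Going by the values given here, none of the measured steps bears on this change; the only step, benzyl in place of 4-methylphenyl on an amide-type nitrogen in a ring, concerns a different part of the shared core and is unreadable in any case. With every measured value sitting at the limit, the step expected from compound 1 to compound 4 in this assay is none beyond the scatter, a step that the limit leaves unreadable from compound 1 to compound 4. Compound 4 is therefore expected to give 150000 nM, with a range from 50000 nM to 500000 nM.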

Compound 4, half-maximal inhibitory concentration: 84800 nM
Estimate against measurement, compound 4: 1.8-fold (0.25 log units) above; low and high end bracket the measured number.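

In this assay, among the compounds shown here, compound 4 gives 84800 nM, the first real number in this small set. The group on the amide-type nitrogen is therefore the first place where a change yields a value rather than only a limit. Putting 4-ethoxyphenyl in place of 4-methoxy-2-methylphenyl, with the same atoms joined differently, gives an at least 1.1-fold lower number from compound 1 to compound 4 (0.07 log units; that floor lies within the scatter); this means that a real gain in strength can be neither claimed nor ruled out. The entry for compound 1 remains a limit, so the step has only a floor, and the set as a whole still sits at the edge of what the assay reads: the limit of > 100000 nM in this assay, at which 3 of the 4 values shown sit.

The compounds shown do not separate the two parts of this change, the loss of the methyl group and the lengthening of methoxy to ethoxy, which a compound carrying 4-methoxyphenyl in this place would begin to do. Also open, on these data alone, is how a longer chain such as 4-propoxyphenyl, or a phenyl bearing an amine or a carboxylic acid, would read in this assay at this same position.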